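Side-chain ester to amide on the shared core

The source may hold more compounds than are shown below. What is called first, only, known or untested is meant among the compounds shown, and "the series" means these compounds.

Measured compounds:
compound 1, `N=C(N)NCCC[C@H](NC(=O)CN(c1nc(Cl)nc2[nH]cnc12)C1CC1)C(=O)OCc1ccccc1`, gives 30.4% in a functional assay on the whole organism (Tail, strain ICR) with Mus musculus as the target, in the tail flick test, with a stated time of 90 min, at a dose of 25 umol/kg by the oral route; a higher number here means a stronger effect of the compound at the dose given, a lower number a weaker effect.
compound 2, `O=C(CN(c1nc(Cl)nc2[nH]cnc12)C1CC1)N[C@@H](CC(=O)OCc1ccccc1)C(=O)OCc1ccccc1`, gives 15.6% in this assay.
compound 3, `O=C(CN(c1nc(Cl)nc2[nH]cnc12)C1CC1)N[C@@H](CCC(=O)OCc1ccccc1)C(=O)OCc1ccccc1`, gives 50% in this assay.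

Compound 3 stands highest of the three numbers. The step of a number 19.6 percentage points higher from compound 1 to compound 3 (beyond the scatter) and the step of a number 34.4 percentage points higher from compound 2 to compound 3 (beyond the scatter) are both beyond the scatter, while the step of a number 14.8 percentage points lower from compound 1 to compound 2 (beyond the scatter) runs downward. All three measured steps alter what hangs on the saturated chain carbon, and in every measured compound the benzyloxycarbonyl end of that chain, where present, is kept.

Compound 4, `NC(=O)CC[C@H](NC(=O)CN(c1nc(Cl)nc2[nH]cnc12)C1CC1)C(=O)OCc1ccccc1`, differs from compound 3 by amino in place of benzyloxy on a carbonyl carbon. Among the compounds with values here, no measured step touches this position: the steps of a number 34.4 percentage points higher from compound 2 to compound 3 (beyond the scatter) and a number 19.6 percentage points higher from compound 1 to compound 3 (beyond the scatter) change the chain that carries the group but leave the benzyloxycarbonyl itself in place, so they bear only indirectly. Within the data shown here, the measured series gives no step from benzyloxycarbonyl to carbamoyl, so the direction is not anchored by data. A modest downward step, a number 15 percentage points lower from compound 3 to compound 4 (beyond the scatter), is expected, with a wide range. Compound 4 is estimated at 35% in this assay, expected between 15% and 60%.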

Compound 4, a percentage reported as activity, at one dose (the size of the read-out at that dose, not a potency): 42.8%
The estimate for compound 4 lay 7.8 percentage points below the measured number; the measured number falls inside the stated range.
By their numbers in this assay, from the lowest: compound 2; then compound 1; then compounds 4 and 3 (each within the scatter of the next).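

In this assay the exchange of benzyloxy for amino on the carbonyl carbon gives a number 7.2 percentage points lower from compound 3 to compound 4 (within the scatter) and so does not separate the two groups, which means that the read-out at this dose does not depend on the benzyloxy and its six-membered aromatic ring at this place. The 2-carbamoylethyl chain also keeps compound 4 clear of the other two side chains, with a number 27.2 percentage points higher from compound 2 to compound 4 (beyond the scatter) and with a number 12.4 percentage points higher from compound 1 to compound 4 (beyond the scatter) in the same direction, so the upper end of this small series now holds both an ester-ended and an amide-ended chain. Nothing at hand gives a reason for these numbers.

Still open, from the compounds shown here alone, is whether a carbamoylmethyl chain, one carbon shorter, would fall away as the shorter ester chain of compound 2 does, which would show whether chain length matters as much with the amide end as with the ester end. Also open, going by these compounds, is how a carboxylic acid or a benzylamino group on the same carbonyl carbon would read in this assay, and whether the benzyloxycarbonyl kept on the other end of the amino acid unit can itself be replaced.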